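The source may report more compounds than this note shows. Statements on the series, on what has been measured and on what is new or still open speak of the compounds shown alone.

Compound 3 `Cc1nc2c3ccccc3ccc2c2nc3c(ccc4ccccc43)c(-c3cccc4ccccc34)c12` carries a naphthalen-1-yl group on the shared core. Going by the values given here, in a functional assay on HCT-116 cells (Homo sapiens) for cytotoxicity, read by MTT assay, with a stated time of 48 h (on this read-out lower numbers stand for stronger inhibition and higher numbers for weaker inhibition), compound 3 gives 20800 nM, one of only two numbers recorded. Its nearest neighbour is compound 1 `Cc1nc2c3ccccc3ccc2c2nc3c(ccc4ccccc43)c(-c3cccc([N+](=O)[O-])c3)c12`, which bears a 3-nitrophenyl group in the same place and gives 13200 nM; the step of a 1.6-fold higher number from compound 1 to compound 3 (0.20 log units; within the scatter) is within the scatter. Compound 2 `COc1ccc(-c2c3ccc4ccccc4c3nc3c2c(C)nc2c4ccccc4ccc32)cc1`, with a 4-methoxyphenyl group, gives only a limit, > 80000 nM. The step of an at least 3.8-fold lower number from compound 2 to compound 3 (0.58 log units; beyond the scatter) is beyond the scatter.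

Compound 4 `Cc1nc2c3ccccc3ccc2c2nc3c(ccc4ccccc43)c(-c3cc([N+](=O)[O-])ccc3N)c12` differs from compound 3 by 2-amino-5-nitrophenyl in place of naphthalen-1-yl on an aromatic carbon. The entering group keeps a nitro group on the phenyl ring, as in compound 1, and the step of a 1.6-fold higher number from compound 1 to compound 3 (0.20 log units; within the scatter) shows that exchanging such a ring for naphthalen-1-yl changed little. Compound 4 is therefore expected to show a step of a 1.6-fold lower number from compound 3 to compound 4 (0.20 log units; within the scatter) that stays within the scatter. Compound 4 is estimated at 13000 nM, with a range from 5000 nM to 35000 nM.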

Compound 4, half-maximal inhibitory concentration: 6010 nM
Beside the measured number, compound 4's estimate is 2.2-fold (0.34 log units) above it; measured number inside the range.
By their numbers in this assay, from the lowest: compound 4; then compounds 1 and 3 (each within the scatter of the next). At a limit, above all of these: compound 2.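

Amino in place of hydrogen on the nitrophenyl ring gives a 2.2-fold lower number from compound 1 to compound 4 (0.34 log units; beyond the scatter) in this assay, so a change on this ring moves the number beyond the scatter even with the nitro group kept. The earlier nitro-bearing ring and naphthalen-1-yl lay within the scatter of each other, yet 2-amino-5-nitrophenyl in place of naphthalen-1-yl gives a 3.5-fold lower number from compound 3 to compound 4 (0.54 log units; beyond the scatter), so this group now stands apart from both. The step of 2-amino-5-nitrophenyl in place of 4-methoxyphenyl, an at least 13-fold lower number from compound 2 to compound 4 (1.12 log units; beyond the scatter), is large, but compound 2 gives only a limit and not a number: the limit of > 80000 nM in this assay, at which 1 of the 4 values shown sits.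

The compounds shown hold the amino group only together with a nitro group on the same ring, so what amino does without nitro stays open. Going by these compounds, whether a hydroxyl group or an acetamide in place of the amino group would keep this step also stays open.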